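Swapping the Dimethylphenyl Ring on a Nitro-Bearing Core

The compounds below may be only part of what the source reports. "The series", "measured", "known", "first", "only" and "open" are said of these compounds alone.

Measured in a functional assay on Molt4/C8 cells (Homo sapiens) for cytotoxicity; on this read-out lower numbers stand for stronger inhibition and higher numbers for weaker inhibition:

Compound 1 `Cc1cccc(C)c1NC(=O)/C=C/C(=O)N1C/C(=C\c2ccccc2)C(=O)/C(=C/c2ccccc2)C1` gives 6600 nM
Compound 2 `Cc1ccc(NC(=O)/C=C/C(=O)N2C/C(=C\c3ccc([N+](=O)[O-])cc3)C(=O)/C(=C/c3ccc([N+](=O)[O-])cc3)C2)cc1C` gives 660 nM
Compound 3 `Cc1ccc(NC(=O)/C=C/C(=O)N2C/C(=C\c3ccccc3)C(=O)/C(=C/c3ccccc3)C2)cc1C` gives 7900 nM

Compound 3 and compound 1 share the same core and differ only in the ring on the amide nitrogen: 2,6-dimethylphenyl in place of 3,4-dimethylphenyl on an amide-type nitrogen. This change produced a 1.2-fold lower number from compound 3 to compound 1 (0.08 log units; within the scatter), so the two numbers are effectively the same.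

Compound 2 is built on a different core, carrying nitro groups; the difference between the two cores is not broken down here. In this assay compound 2 gives the lowest of the three numbers, and both compound 1 and compound 3 sit well beyond the scatter above it.

Compound 4 `Cc1cccc(C)c1NC(=O)/C=C/C(=O)N1C/C(=C\c2ccc([N+](=O)[O-])cc2)C(=O)/C(=C/c2ccc([N+](=O)[O-])cc2)C1` is not yet measured. It relates to compound 2 exactly as compound 1 relates to compound 3: 2,6-dimethylphenyl in place of 3,4-dimethylphenyl on an amide-type nitrogen. The place of the change is the same in both pairs, so this is the same change made on the nitro-bearing core.

Because the same change gave a 1.2-fold lower number from compound 3 to compound 1 (0.08 log units; within the scatter) on the other core, the step is expected to stay small: a 1.1-fold lower number from compound 2 to compound 4 (0.04 log units; within the scatter). Compound 4 is therefore estimated at 600 nM in this assay. Within the data shown here, for compound 4 the expected range runs from 280 nM to 1300 nM, allowing for the usual scatter and for the fact that only one earlier example of this change exists.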

Compound 4, half-maximal inhibitory concentration: 210 nM
Compound 4: middle estimate off by 2.9-fold (0.46 log units), on the high side, and the stated range ends above it.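

In this assay, placing 2,6-dimethylphenyl instead of 3,4-dimethylphenyl on the amide-type nitrogen of the nitro-bearing core gives a 3.1-fold lower number from compound 2 to compound 4 (0.50 log units; beyond the scatter), a step that is modest but beyond the usual scatter of repeated measurements. At first sight this change seems to matter on the nitro-bearing core and not on the other one, yet the two steps cannot be told apart once the scatter in both is counted: the same change on two cores in this assay, a 1.2-fold lower number (0.08 log units; within the scatter) from compound 3 to compound 1 and a 3.1-fold lower number (0.50 log units; beyond the scatter) from compound 2 to compound 4, 2.6-fold (0.42 log units) apart, within the scatter of two such steps So the data fit a change that carries over from one core to the other with a similar effect, but they do not prove that, and they do not show that the nitro-bearing core truly enlarges the step, since a single pair on each core is too little to settle either reading.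

The compounds shown leave open whether the step would look the same on a core carrying a methoxy group or an amine in place of the nitro groups. They also leave open how a plain phenyl ring, without either methyl group, would compare on the amide-type nitrogen of each core.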